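This account rests on a few compounds, and the source may have more. Where it says the series, first, only, none or still open, it means among the compounds named here.

Among the compounds with values here, in a physicochemical assay, read by spectrophotometry, with a stated time of 10 min (on this read-out higher numbers stand for weaker inhibition and lower numbers for stronger inhibition), compound 1 `Cc1ccc2nc(NCCCCOc3cc(O)c4c(=O)cc(-c5ccccc5)oc4c3)sc2c1` gives 8.79 ug/mL, the higher of the two numbers measured so far. Within the data shown here, the only other measured compound, compound 2 `O=c1cc(-c2ccccc2)oc2cc(OCCCCNc3nc4ccc(Cl)cc4s3)cc(O)c12`, gives 4.16 ug/mL. Compound 3 `O=c1cc(-c2ccccc2)oc2cc(OCCCCNc3nc4ccc(I)cc4s3)cc(O)c12` has yet to be measured in this assay. It differs from compound 1 as follows: iodo in place of methyl on an aromatic carbon. In short, 6-methyl-1,3-benzothiazol-2-yl becomes 6-iodo-1,3-benzothiazol-2-yl. Among the measured compounds shown here, one measured step bears on this change, chloro in place of methyl on the same carbon, and it is modest: a 2.1-fold lower number from compound 1 to compound 2 (0.32 log units; beyond the scatter). For the measured compounds named here, no measured compound carries iodo, so this single step is a limited guide. On the strength of that step, a change of similar modest size towards a lower number is expected, although it may not clear the usual scatter. The expected change is a 2.0-fold lower number from compound 1 to compound 3 (0.29 log units; within the scatter). For compound 3, the estimated value is 4.5 ug/mL, with an expected range from 2.2 ug/mL to 8.8 ug/mL.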

Compound 3, half-maximal inhibitory concentration: 9.84 ug/mL
Compound 3: the middle estimate sits 2.2-fold (0.34 log units) below what was measured, and the stated range ends below it.
By their numbers in this assay, from the lowest: compound 2; then compounds 1 and 3 (each within the scatter of the next).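

In this assay, the lower number seen with chloro does not extend to iodo on this aromatic carbon of the 1,3-benzothiazol-2-yl unit: exchanging chloro for iodo gives a 2.4-fold higher number from compound 2 to compound 3 (0.37 log units; beyond the scatter) and so separates the two groups beyond the scatter. Iodo and methyl, by contrast, cannot be told apart at this position, with a 1.1-fold higher number from compound 1 to compound 3 (0.05 log units; within the scatter) as the step between them, so of these three groups only chloro stands out, with the lowest number and thus the strongest inhibition. Nothing available explains why chloro and iodo part in this way.

Open, from the compounds shown here alone, is how bromo, fluoro or methoxy on this same carbon would read, and therefore whether chloro is a lone case or one member of a wider set of groups with lower numbers. Also open, going by these compounds, is whether the advantage of chloro over iodo would survive with a longer chain joining the amino group to the shared core, or with an added amine or carboxylic acid elsewhere on the molecule.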